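The source may hold more compounds than are shown below. What is called first, only, known or untested is meant among the compounds shown, and "the series" means these compounds.

The measured compounds:

Compound 1 `COc1ccc(/C=C/C(=O)c2ccc(NC(=O)CO[N+](=O)[O-])cc2)cc1` gives 51% in a functional assay on the whole organism (strain albino) for inhibition, with Rattus norvegicus as the target, read by paw edema, with stated times of 30 min and 4 h, at a dose of 100 mg/kg by the oral route; on this read-out higher numbers stand for more inhibition at the one dose given (going by the name of the read-out) and lower numbers for less inhibition.
Compound 2 `COc1ccc(/C=C/C(=O)c2ccc(NC(=O)C(C)O[N+](=O)[O-])cc2)cc1` gives 43% in this assay.

Compound 1 has the highest of the two numbers in this assay, but its nearest neighbour, compound 2, lies within the scatter, so the two cannot be ordered. Among the compounds with values here, the one measured step, a number 8 percentage points lower from compound 1 to compound 2 (within the scatter), alters the saturated chain carbon next to the ester oxygen and leaves the nitrooxy group in place.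

Compound 3 `COc1ccc(/C=C/C(=O)c2ccc(NC(=O)COc3ccc(C(C)=O)cc3)cc2)cc1` is not yet measured. It differs from compound 1 in one place: 4-acetylphenyl in place of nitro on an oxygen on a saturated carbon. This change touches the nitrooxy end itself, which the step from compound 1 to compound 2 did not; that step was within the scatter, so it bears only indirectly on the new change, and it offers no guide to the size of a swap of nitro for 4-acetylphenyl. With nothing measured that speaks to this exchange, the step of a number 6 percentage points lower from compound 1 to compound 3 (within the scatter) is expected to stay near the level of compound 1, with the range widened for the uncertainty. Compound 3 is therefore estimated at 45%, between 28% and 62%.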

Compound 3, a percentage reported as inhibition, in the whole organism at one dose (the size of the read-out at that dose, not a potency): 33%
Compound 3: middle estimate off by 12 percentage points, on the high side, and the stated range covers the measured number.
By their numbers in this assay, from the lowest: compounds 3, 2 and 1 (each within the scatter of the next, the first and the last beyond it).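

In this assay, the exchange of nitro for 4-acetylphenyl on an oxygen on a saturated carbon gives a number 18 percentage points lower from compound 1 to compound 3 (beyond the scatter). Within the data shown here, this is the first step that lies beyond the scatter, so the group carried on this oxygen can matter in a way that the methyl on the chain carbon in compound 2 did not show, although the step is modest. Inhibition does not vanish without the nitrooxy end, as compound 3 still gives 33%, but no measurement at hand says what lies behind the step.

Among these compounds, the single exchange does not separate the loss of nitro from the arrival of 4-acetylphenyl, and a plain phenyl or a hydroxyl on the same oxygen would be needed to tell these two apart. From the compounds shown here alone, it also remains open whether other groups on this oxygen, such as a 4-carboxyphenyl or a 4-aminophenyl, would stay near compound 1 or fall further, and whether a longer chain carrying the nitrooxy group would change the reading at all.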